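The source may report more compounds than this note shows. Statements on the series, on what has been measured and on what is new or still open speak of the compounds shown alone.

Compound 1 `CCCCCCCCNC1=CC(=O)C=C(C[C@]2(C)[C@@H](C)CC[C@]3(C)C(C)=CCC[C@@H]23)C1=O`: 17000 nM
Compound 2 `CCCCNC1=CC(=O)C=C(C(C)(C)C)C1=O`: 11000 nM

In an ADME assay on HaCaT cells (Homo sapiens) for cytotoxicity, read by MTT assay, with a stated time of 72 h (on this read-out higher numbers stand for weaker inhibition and lower numbers for stronger inhibition), compound 1 gives 17000 nM and compound 2 gives 11000 nM, and these two numbers lie within the scatter of each other. Compound 3 `CC1=CCC[C@H]2[C@](C)(CC3=CC(=O)C=CC3=O)[C@@H](C)CC[C@]12C`, not yet measured, differs from compound 1 by hydrogen in place of octylamino on a double-bonded ring carbon, with hydrogen in place of octylamino on a double-bonded ring carbon. Among the compounds with values here, no measured pair shows this change directly, so any forecast is uncertain. A moderate move towards stronger inhibition is expected, an estimated 2.8-fold lower number from compound 1 to compound 3 (0.45 log units; beyond the scatter). For compound 3 the estimated value is 6000 nM, with an expected range of 1500 nM to 20000 nM.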

Compound 3, half-maximal inhibitory concentration: 37000 nM
Beside the measured number, compound 3's estimate is 6.2-fold (0.79 log units) below it; the measured number lies above the stated range.
By their numbers in this assay, from the lowest: compounds 2 and 1 (each within the scatter of the next); then compound 3.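

In this assay, replacing octylamino with hydrogen on the double-bonded ring carbon gives a 2.2-fold higher number from compound 1 to compound 3 (0.34 log units; beyond the scatter), a modest move towards weaker inhibition. Within the data shown here, this is the first direct reading at this position: on the core of compound 1, the octylamino group goes with the lower number. Nothing measured here accounts for the step.

On these data alone, whether a free amino group, a hexylamino chain or a methoxy group at this carbon would give a lower or higher number remains open. So does whether the same step would appear on a different core.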